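A few compounds are considered here, and "the series" means these few. Any claim that something is new, unique, unknown or untested is made for them only; others in the source may bear on it.

In a functional assay on A549 cells (Homo sapiens) for inhibition, read by sulforhodamine B assay, with a stated time of 48 h (a higher number here means a weaker inhibitor of growth, a lower number a stronger inhibitor of growth), compound 1 `O=C(Cc1csc2nc(-c3ccc(Br)cc3)cn12)N/N=C/c1ccccc1` gives 13500 nM, compound 2 `O=C(Cc1csc2nc(-c3ccc(Br)cc3)cn12)N/N=C/c1ccccc1O` gives 6170 nM and compound 3 `O=C(Cc1csc2nc(-c3ccc(Br)cc3)cn12)N/N=C/c1ccc(O)cc1` gives 10700 nM. Compound 2 stands at the low end of these three numbers, but it is clearly separated only in a 2.2-fold lower number from compound 1 to compound 2 (0.34 log units; beyond the scatter), and not in a 1.7-fold higher number from compound 2 to compound 3 (0.24 log units; within the scatter). Compound 4 `COc1cccc(OC)c1/C=N/NC(=O)Cc1csc2nc(-c3ccc(Br)cc3)cn12` differs from it by 2,6-dimethoxyphenyl in place of 2-hydroxyphenyl on a carbon with a double bond to nitrogen. Among the compounds with values here, no measured compound carries methoxy, so the nearest guides are the hydroxy steps, the modest 2.2-fold lower number from compound 1 to compound 2 (0.34 log units; beyond the scatter) and the smaller 1.3-fold lower number from compound 1 to compound 3 (0.10 log units; within the scatter). A small upward move in this assay is therefore expected, near the scatter: a 1.5-fold higher number from compound 2 to compound 4 (0.16 log units; within the scatter) is the estimated step. Compound 4 is estimated at 9000 nM, with an expected range of 4000 nM to 20000 nM.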

Compound 4, concentration for 50% growth inhibition: 11500 nM
Compound 4: middle estimate off by 1.3-fold (0.11 log units), on the low side, and the stated range covers the measured number.
By their numbers in this assay, from the lowest: compounds 2, 3, 4 and 1 (each within the scatter of the next, the first and the last beyond it).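

In this assay, 2,6-dimethoxyphenyl on this carbon is not separated from any earlier aryl group (a 1.9-fold higher number from compound 2 to compound 4 (0.27 log units; within the scatter); a 1.1-fold higher number from compound 3 to compound 4 (0.03 log units; within the scatter); a 1.2-fold lower number from compound 1 to compound 4 (0.07 log units; within the scatter)). A hydroxy group is therefore not shown to be needed at this position, since a ring without one, and with no hydrogen-bond donors, stays within the scatter of compound 2. No supporting data bear on why these steps are so small. Still open, on these data alone, is whether an amine or a carboxylic acid on this ring would move the number beyond the scatter, and whether either methoxy alone would match the 2,6-dimethoxyphenyl result.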